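Swapping the Benzofuranyl Arm of Compound 2 for Phenyl

This account rests on a few compounds, and the source may have more. Where it says the series, first, only, none or still open, it means among the compounds named here.

Compound 1 `COc1nc(N)nc2c1c(-c1cc3ccccc3o1)cn2[C@@H]1O[C@H](CO)[C@@H](O)[C@H]1O`: in a functional assay on HeLa S3 cells (Homo sapiens) for antiproliferative activity, read by XTT assay, with a stated time of 72 h (a higher number here means a weaker inhibitor, a lower number a stronger inhibitor), compound 1 gives only a limit, > 20000 nM.
Compound 2 `Nc1nc(N)c2c(-c3cc4ccccc4o3)cn([C@@H]3O[C@H](CO)[C@@H](O)[C@H]3O)c2n1`: in this assay compound 2 gives only a limit, > 20000 nM.
Compound 3 `Cc1nc(N)c2c(-c3cc4ccccc4o3)cn([C@@H]3O[C@H](CO)[C@@H](O)[C@H]3O)c2n1`: in this assay compound 3 gives only a limit, > 20000 nM.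

Compound 2 stands at the limit of this assay, and so do the two other values shown (the limit of > 20000 nM in this assay, at which 3 of the 3 values shown sit). The step that the two limits leave unreadable from compound 1 to compound 2 and the step that the two limits leave unreadable from compound 2 to compound 3 are both unreadable, since each end sits at that limit. Compound 4 `Nc1nc(N)c2c(-c3ccccc3)cn([C@@H]3O[C@H](CO)[C@@H](O)[C@H]3O)c2n1` differs from compound 2 by phenyl in place of 1-benzofuran-2-yl on an aromatic carbon. Among the measured compounds shown here, none of the measured steps touches this part of the molecule, and the steps that are measured give no size at all, so no direction in this assay can be read for it. Compound 4 is therefore expected to give 20000 nM in this assay, with the range 6000 nM to 60000 nM. The step of a number no higher from compound 2 to compound 4 (the limit leaves the size open) that this estimate means is expected to be no more than the scatter, most likely with compound 4 again reported as a limit.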

Compound 4, half-maximal inhibitory concentration: > 20000 nM
Compound 4: a limit, no number; the forecaster's own chance of this, stated with the estimate: 75%; the middle value lies on the limit itself.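

In this assay compound 4 gives only a limit, > 20000 nM, so phenyl in place of 1-benzofuran-2-yl leaves no readable step between compound 2 and compound 4. How compounds 1, 2, 3 and 4 rank against one another stays open, since all sit at one limit: the limit of > 20000 nM in this assay, at which 4 of the 4 values shown sit.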